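The source may report more compounds than this note shows. Statements on the series, on what has been measured and on what is new or still open speak of the compounds shown alone.

Measured in a functional assay on HeLa cells (Homo sapiens), read by colorimetric assay, with a stated time of 48 h; a lower number here means a stronger inhibitor, a higher number a weaker inhibitor:
- compound 1 `OC[C@@H](O)[C@H]1O[C@@H](n2cnc3c(Cl)nc(Cl)nc32)[C@H](O)[C@@H]1O`: 47100 nM
- compound 2 `CC(=O)OC[C@@H](OC(C)=O)[C@H]1O[C@@H](n2cnc3c(Cl)ncnc32)[C@H](OC(C)=O)[C@@H]1OC(C)=O`: > 100000 nM (a limit of the assay)
- compound 3 `CC(=O)OC[C@@H](OC(C)=O)[C@H]1O[C@@H](n2cnc3c(-c4ccccc4)ncnc32)[C@H](OC(C)=O)[C@@H]1OC(C)=O`: > 100000 nM (a limit of the assay)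

Compound 2 gives > 100000 nM in this assay, which is a limit of the assay and not a number. Going by these compounds, this places compound 2 at the limit of > 100000 nM in this assay, at which 2 of the 3 values shown sit, so its true strength is unknown.

Compound 4 `CC(=O)OC[C@@H](OC(C)=O)[C@H]1O[C@@H](n2cnc3c(N)nc(Cl)nc32)[C@H](OC(C)=O)[C@@H]1OC(C)=O` has not yet been measured. It keeps the sugar-derived ring and the acetoxy groups of compound 2 and changes only the group on a saturated ring carbon, next to the ring oxygen: a group of 11 heavy atoms (5 carbon, 5 nitrogen, 1 chlorine; one five-membered aromatic ring with 2 hetero atoms, one six-membered aromatic ring with 2 hetero atoms) in place of a group of 10 heavy atoms (5 carbon, 4 nitrogen, 1 chlorine; one five-membered aromatic ring with 2 hetero atoms, one six-membered aromatic ring with 2 hetero atoms), on a saturated ring carbon.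

Within the data shown here, the one measured step bearing on this change is a step that the two limits leave unreadable from compound 2 to compound 3, so it offers no size to carry over. Among the measured compounds shown here, compound 1 gives the only true number, 47100 nM, but it carries no acetoxy groups, unlike compound 4. Compound 2 and compound 3 both carry those groups, and neither gave a number. The expectation is therefore that compound 4 stays weak, close to that limit, and it may well return only a limit too.

The expected change is an at least 1.1-fold lower number from compound 2 to compound 4 (0.04 log units; that floor lies within the scatter), with no clear direction anticipated.

For compound 4 the estimate is 90000 nM, with an expected range of 30000 nM to 200000 nM.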

Compound 4, half-maximal inhibitory concentration: > 100000 nM
Compound 4: only a limit was reported; the forecaster's own chance of this, stated with the estimate: 65%; at least 1.1-fold (0.04 log units) between middle value and limit.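

In this assay compound 4 gives > 100000 nM, which is a limit of the assay and not a number. Compound 2 also sits at a limit, so the step from compound 2 to compound 4 cannot be read. The compounds shown leave open how strong any of the compounds carrying acetoxy groups truly is.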